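Cytotoxicity notes: pyridyl to cyanophenyl amide exchange

A few compounds are considered here, and "the series" means these few. Any claim that something is new, unique, unknown or untested is made for them only; others in the source may bear on it.

Values in a toxicity assay on THP-1 cells (Homo sapiens) for inhibition; on this read-out higher numbers stand for lower toxicity in this test and lower numbers for higher toxicity in this test:
compound 1 `Cn1c(-c2ccc(Br)cc2)cnc1NC(=O)c1ccc(F)cc1` — 46000 nM
compound 2 `COc1ccc(-c2cnc(NC(=O)c3cccnc3)n2C)cc1` — > 100000 nM
compound 3 `O=C(Nc1ncc(-c2ccccc2)o1)c1ccc(Cl)cc1` — 10000 nM

Among the measured compounds shown here, compound 2 stands at the top of the measured range: its result > 100000 nM is a limit of the assay, not a number, and it is the one value sitting at the limit of > 100000 nM in this assay, at which 1 of the 3 values shown sits. For the measured compounds named here, compounds 1 and 3 give numbers; no pair of measured compounds differs in a single place, so their values only show where they lie.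

Compound 4 `COc1ccc(-c2cnc(NC(=O)c3ccccc3C#N)n2C)cc1` differs from compound 2 by 2-cyanophenyl in place of pyridin-3-yl on a carbonyl carbon. Going by the values given here, no measured step tells the size of such a change, and in this assay no step beyond the usual scatter is expected. Compound 4 is therefore estimated at 70000 nM, with a range of 25000 nM to 150000 nM. The expected step is an at least 1.4-fold lower number from compound 2 to compound 4 (0.15 log units; that floor lies within the scatter).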

Compound 4, half-maximal cytotoxic concentration: > 100000 nM
Compound 4: no number, only a limit; the forecaster's own chance of this, stated with the estimate: 40%; at least 1.4-fold (0.15 log units) between middle value and limit.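

Compound 2 and compound 4 both give only a limit in this assay, so no step can be read between them: the limit of > 100000 nM in this assay, at which 2 of the 4 values shown sit.

The compounds shown leave open how far pyridin-3-yl and 2-cyanophenyl on the carbonyl carbon differ on this read-out.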